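The compounds below may be only part of what the source reports. "The series", "measured", "known", "first", "only" and "open" are said of these compounds alone.

Measured compounds:
compound 1 `C/C(C(=O)NC1CC1)=C(/C)c1ccccc1` — in a toxicity assay on the whole organism (strain Icem-CET (SPF Caw)) for cytotoxicity, with Mus musculus as the target (on this read-out lower numbers stand for an effect already at smaller amounts and higher numbers for an effect only at larger amounts of compound), compound 1 gives 150 mg/kg
compound 2 `C#CCNC(=O)/C(C)=C(\C)c1ccc(C)cc1` — in this assay compound 2 gives 150 mg/kg
compound 3 `C/C(C(=O)NC1CC1)=C(/C)c1ccc(Cl)cc1` — in this assay compound 3 gives 150 mg/kg

Compound 3 sits level with compounds 1 and 2 at the digits shown; its nearest neighbour is compound 1 and its furthest is compound 2, and neither gap goes beyond the scatter. Compound 4 `C/C(C(=O)NC1CC1)=C(/C)c1ccc(C)cc1` has not yet been measured. From compound 3 it differs by methyl in place of chloro on an aromatic carbon. For the measured compounds named here, one measured step bears on this position: no change at the digits printed from compound 1 to compound 3 (within the scatter). Compound 2 carries a methyl on its aromatic ring together with a different amide side chain, and its reading sits at the same digits as those of compounds 1 and 3, again within the scatter. Across the three measured compounds the read-out has not moved for hydrogen, chloro or methyl on that ring, so the step of no change at the digits printed from compound 3 to compound 4 (within the scatter) is expected to stay within the scatter, with no direction favoured. Compound 4 is therefore estimated at 150 mg/kg in this assay, with a range from 75 mg/kg to 300 mg/kg.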

Compound 4, dose for half-maximal effect: 150 mg/kg
Estimate against measurement, compound 4: no gap at the digits printed, within the range that was stated.
By their numbers in this assay, from the lowest: compounds 1, 2, 3 and 4 (each within the scatter of the next).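

In this assay, exchanging one single-heavy-atom substituent for another at the aromatic carbon para to a large group gives no change at the digits printed from compound 3 to compound 4 (within the scatter) for methyl in place of chloro, so hydrogen, chloro and methyl can now be compared at this position with the cyclopropyl amide held constant. The added methyl comparison, this time against hydrogen, gives no change at the digits printed from compound 1 to compound 4 (within the scatter), and none of the listed compounds goes against this flat reading at that carbon. For the compounds shown here, the new compound also isolates the amide side chain for the first time, with the ring methyl held constant: cyclopropyl in place of propargyl on an amide-type nitrogen gives no change at the digits printed from compound 2 to compound 4 (within the scatter), whereas compounds 2 and 3 differ in two places.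

The compounds shown leave open whether the reading stays level with an amine or a carboxylic acid on that aromatic carbon, or with a longer chain on the amide nitrogen. No supporting data are available to explain why the read-out stays level across these changes.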